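Swapping the Phenyl Substituent for a Heteroaromatic Ring

This account rests on a few compounds, and the source may have more. Where it says the series, first, only, none or still open, it means among the compounds named here.

Compound 1 `O=C1Nc2ccc(-n3cncn3)cc2C(CNC(=O)c2ccc(F)cc2)(C(F)(F)F)O1`: 572 nM
Compound 2 `O=C1Nc2ccccc2C(CNC(=O)c2ccc(F)cc2)(C(F)(F)F)O1`: 95 nM
Compound 3 `O=C1Nc2ccc(-c3ccccc3)cc2C(CNC(=O)c2ccc(F)cc2)(C(F)(F)F)O1`: 1480 nM

Three compounds share one core and differ only in the group on a single aromatic carbon. In an assay for inhibition of very long chain fatty acid elongase 6 (Homo sapiens) (a higher number here means a weaker inhibitor, a lower number a stronger inhibitor), compound 2 gives 95 nM, compound 1 gives 572 nM and compound 3 gives 1480 nM. Compound 3 therefore carries the highest number of the three: a 16-fold higher number from compound 2 to compound 3 (1.19 log units; beyond the scatter), and a 2.6-fold higher number from compound 1 to compound 3 (0.41 log units; beyond the scatter).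

Compound 4 `O=C1Nc2ccc(-n3ccccc3=O)cc2C(CNC(=O)c2ccc(F)cc2)(C(F)(F)F)O1` arises from compound 3 by one change: a group of 7 heavy atoms (5 carbon, 1 nitrogen, 1 oxygen; one six-membered aromatic ring with 1 hetero atom) in place of a group of 6 heavy atoms (6 carbon; one six-membered aromatic ring of carbon only), on an aromatic carbon. The step that bears most directly on this is a 2.6-fold higher number from compound 1 to compound 3 (0.41 log units; beyond the scatter), in which phenyl replaced the 1H-1,2,4-triazol-1-yl group and the number rose modestly; the move back toward a ring bearing a hetero atom points to a modest fall in this assay. Compound 4 is therefore expected to give about 600 nM, within 200 nM to 1800 nM, an expected step of a 2.5-fold lower number from compound 3 to compound 4 (0.39 log units; beyond the scatter).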

Compound 4, half-maximal inhibitory concentration: 106 nM
The estimate for compound 4 lay 5.7-fold (0.75 log units) above the measured number, outside the stated range (below it).
By their numbers in this assay, from the lowest: compounds 2 and 4 (each within the scatter of the next); then compound 1; then compound 3.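

In this assay, a ring on this aromatic carbon need not cost activity, as the phenyl of compound 3 had suggested: a 14-fold lower number from compound 3 to compound 4 (1.14 log units; beyond the scatter), while a 1.1-fold higher number from compound 2 to compound 4 (0.05 log units; within the scatter) shows that the new ring leaves the number level with that of the compound carrying hydrogen. Hetero atoms alone do not settle the outcome, since the triazolyl ring of compound 1 also carries them, yet a 5.4-fold lower number from compound 1 to compound 4 (0.73 log units; beyond the scatter). Nothing available explains these differences. The compounds shown leave open how a pyridyl ring, which lacks the carbonyl, would compare at this carbon, and whether a small group such as methoxy would match hydrogen.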